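Rat clearance notes on a trimmed amide analogue

This account rests on a few compounds, and the source may have more. Where it says the series, first, only, none or still open, it means among the compounds named here.

Measured so far:
- compound 1 `CCCCCOC(=O)N1CCN(C(=O)[C@H](CCC(=O)O)NC(=O)c2cc(N3CCC(C(=O)NCC)CC3)nc(-c3ccccc3)n2)CC1`: 8 mL/min/kg
- compound 2 `CCCCCOC(=O)N1CCN(C(=O)[C@H](CCC(=O)O)NC(=O)c2nc(-c3ccccc3)cc(N3CCC(CN)CC3)n2)CC1`: 16 mL/min/kg

In an in vivo ADME assay on the whole organism (strain Sprague-Dawley) for pharmacokinetics, with Rattus norvegicus as the target (a lower number here means slower removal, a higher number faster removal of the compound), compound 1 gives 8 mL/min/kg, the lower of the two numbers in hand. Compound 2 gives 16 mL/min/kg in this assay, a figure within the usual scatter of the value for compound 1, so no ordering of the two can be read from these data. Among the measured compounds shown here, the set holds no pair of measured compounds that differ in one place, so no measured step size guides the next change.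

Compound 3 `CCCCCOC(=O)N1CCN(C(=O)[C@H](CCC(=O)O)NC(=O)c2cc(N3CCC(C(N)=O)CC3)nc(-c3ccccc3)n2)CC1` is not yet measured in this assay. It departs from compound 1 by hydrogen in place of ethyl on an amide-type nitrogen. Nothing in the two measured compounds isolates the effect of this change. The step from compound 1 to compound 3 is expected to be no change at the digits printed from compound 1 to compound 3 (within the scatter), with no direction beyond the scatter. Compound 3 is accordingly expected to give 8 mL/min/kg, within a range of 4 mL/min/kg to 16 mL/min/kg.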

Compound 3, clearance: 68 mL/min/kg
Estimate against measurement, compound 3: 8.5-fold (0.93 log units) below; the measured number lies above the stated range.
By their numbers in this assay, from the lowest: compounds 1 and 2 (each within the scatter of the next); then compound 3.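

In this assay, among the compounds shown here, going from 4-(ethylcarbamoyl)piperidin-1-yl to 4-carbamoylpiperidin-1-yl gives an 8.5-fold higher number from compound 1 to compound 3 (0.93 log units; beyond the scatter), the first single-place step and one that lies beyond the scatter. For the compounds shown here, the position is therefore not silent: the ethyl on this amide-type nitrogen, a small group, carries a measurable share of the difference between slow and fast removal, which the earlier compounds could not show. Nothing measured here bears on the reason for the step.

Still open, from the compounds shown here alone, is whether any carbon substituent on this nitrogen holds the lower number, or whether it depends on ethyl itself; a methyl or a longer chain such as propyl would separate the two. Also open, going by these compounds, is whether the same step appears on other members.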